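Predicting the Effect of Acylating an Aromatic Amine

The source may hold more compounds than are shown below. What is called first, only, known or untested is meant among the compounds shown, and "the series" means these compounds.

Compound 3 `COc1ccc(-c2nn3cc(-c4cccc(N)c4)nc3s2)cc1` gave only a limit in a functional assay on CCRF-CEM cells (Homo sapiens) for inhibition, read by cell counting, with a stated time of 3 days (on this read-out higher numbers stand for weaker inhibition and lower numbers for stronger inhibition), namely >= 250000 nM. Compound 1 `C=C(Br)C(=O)Nc1cccc(-c2cn3nc(-c4ccc(OCC)cc4)sc3n2)c1` gives 1400 nM in this assay, and compound 2 `C=C(Br)C(=O)Nc1cccc(-c2cn3nc(-c4ccc(C)cc4)sc3n2)c1` gives 1700 nM. Among the compounds with values here, the single measured step, a 1.2-fold higher number from compound 1 to compound 2 (0.08 log units; within the scatter), alters a group on an aromatic carbon and leaves the amide untouched, so it says nothing about the change in hand. Compound 4 `C=C(Br)C(=O)Nc1cccc(-c2cn3nc(-c4ccc(OC)cc4)sc3n2)c1` differs from compound 3 by (1-bromoethenyl)carbonyl in place of hydrogen on a nitrogen on an aromatic ring. Within the data shown here, no measured step covers that change, but compounds 1 and 2, which carry the same (1-bromoethenyl)carbonyl group, both sit near the same number, so compound 4 is expected to land alongside them, a step of an at least 160-fold lower number from compound 3 to compound 4 (2.22 log units; beyond the scatter). Compound 4 is therefore estimated at 1500 nM, plausibly between 500 nM and 5000 nM.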

Compound 4, half-maximal inhibitory concentration: 1200 nM
The estimate for compound 4 lay 1.3-fold (0.10 log units) above the measured number; the range from low to high includes it.
By their numbers in this assay, from the lowest: compounds 4, 1 and 2 (each within the scatter of the next). At a limit, above all of these: compound 3.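

The change from amino to ((1-bromoethenyl)carbonyl)amino now has a direct reading, an at least 200-fold lower number from compound 3 to compound 4 (2.31 log units; beyond the scatter). Compound 3 gives only a limit, so that step is a minimum size: the limit of >= 250000 nM in this assay, at which 1 of the 4 values shown sits. With the amide in place, exchanging the group on the aromatic carbon changes little, a 1.4-fold lower number from compound 2 to compound 4 (0.15 log units; within the scatter) and a 1.2-fold lower number from compound 1 to compound 4 (0.07 log units; within the scatter).

The compounds shown do not tell which part of the (1-bromoethenyl)carbonyl group matters. An acetyl group, or an acryloyl group without the bromine, on the same nitrogen would begin to separate the amide from the bromoalkene.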